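A few compounds are considered here, and "the series" means these few. Any claim that something is new, unique, unknown or untested is made for them only; others in the source may bear on it.

Working notes on the series.

Two compounds share the adenosine-derived core; a third extends the set. Compound 1 `Nc1ncnc2c1ncn2[C@@H]1O[C@H](CNC(=O)C[C@H](N)C(=O)O)[C@@H](O)[C@H]1O` carries an amide-linked side chain; in an assay for inhibition of tRNA (cytosine(38)-C(5))-methyltransferase (Homo sapiens), with a stated time of 5 min, tested at 100 uM (a higher number here means more inhibition at the concentration tested (going by the name of the read-out), a lower number less inhibition), compound 1 gives no result reported. Compound 2 `Nc1ncnc2c1ncn2[C@@H]1O[C@H](CN(CC[C@H](N)C(=O)O)CC2CCC2)[C@@H](O)[C@H]1O` carries a tertiary amine bearing the amino-acid chain and a cyclobutylmethyl group; in this assay compound 2 gives 32%. Among the measured compounds shown here, as the only number in hand, compound 2 is the sole reference point for this assay, and no comparison between measured compounds can be drawn from it.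

Compound 3 `C#CCCN(CC[C@H](N)C(=O)O)C[C@H]1O[C@@H](n2cnc3c(N)ncnc32)[C@H](O)[C@@H]1O` is not yet measured. It differs from compound 2 in one place: propargyl in place of cyclobutyl on a saturated chain carbon bound to an amine nitrogen. The change swaps one small carbon substituent on the amine for another of similar size, and nothing in the measured set indicates how this assay responds to that part of the molecule.

For compound 3 the step from compound 2 is expected to be small, a number 2 percentage points lower from compound 2 to compound 3 (within the scatter), with no direction favoured beyond the scatter. Compound 3 is therefore estimated at 30% in this assay, within a range of 10% to 50%.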

Compound 3, a percentage reported as inhibition, at one concentration (the size of the read-out at that concentration, not a potency): 30.2%
For compound 3 the middle estimate is 0.2 percentage points below the measured one, and the stated range covers the measured number.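

In this assay, the exchange of cyclobutyl for propargyl on a saturated chain carbon bound to an amine nitrogen gives a number 1.8 percentage points lower from compound 2 to compound 3 (within the scatter), so this read-out does not separate the two compounds. Among the compounds shown here, this gives the first reading at this position: a four-membered carbon ring and an open chain with a triple bond, read one bond further out as cyclobutylmethyl and but-3-yn-1-yl, show no difference beyond the scatter at the single concentration tested. Nothing measured for these compounds bears on why the two groups read alike.

Still open, as far as these compounds go, is how this assay responds when this substituent on the amine nitrogen is of another kind, such as a benzyl group, a chain ending in a primary amine or a carboxylic acid, or a longer alkyl chain. For the compounds shown here, also open is whether any change at this position moves the read-out beyond the scatter, as the single step available here cannot show how far the position can be varied with the rest of the molecule unchanged.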